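A few compounds are considered here, and "the series" means these few. Any claim that something is new, unique, unknown or untested is made for them only; others in the source may bear on it.

For the measured compounds named here, in a functional assay on DU-145 cells (Homo sapiens) for inhibition, read by trypan blue exclusion, with a stated time of 72 h (a higher number here means a weaker inhibitor, a lower number a stronger inhibitor), compound 3 (`COc1ccc(S(=O)(=O)c2cc3cnc(Nc4cccc5[nH]ccc45)nc3n(C)c2=O)cc1`) gives 5000 nM and stands highest of the three numbers measured so far. Compound 1 (`Cn1c(=O)c(S(=O)(=O)c2ccc(F)cc2F)cc2cnc(Nc3cccc4[nH]ccc34)nc21`) at 750 nM and compound 2 (`Cn1c(=O)c(S(=O)(=O)c2ccc(Cl)cc2)cc2cnc(Nc3ccc4[nH]ccc4c3)nc21`) at 250 nM both lie lower, each beyond the scatter from compound 3. Compound 4 (`Cn1c(=O)c(S(=O)(=O)c2ccc(Cl)cc2)cc2cnc(Nc3cccc4[nH]ccc34)nc21`) is still unmeasured and differs from compound 3 in one place (chloro in place of methoxy on an aromatic carbon), with chloro in place of methoxy on an aromatic carbon, para to a large group. Going by the values given here, one measured step bears on this group: a 6.7-fold higher number from compound 1 to compound 3 (0.82 log units; beyond the scatter) is modest but beyond the scatter, and there 4-methoxyphenyl took the place of 2,4-difluorophenyl on a sulfonyl sulfur. Among the compounds with values here, no measured step goes directly from methoxy to chloro. Within the data shown here, the 4-chlorophenyl group does occur in compound 2, but no measured step isolates it, so that compound gives only loose support. Leaving the 4-methoxyphenyl group is therefore expected to bring a change of similar size in this assay toward a lower number, meaning a stronger inhibitor. The expected step is a 7.1-fold lower number from compound 3 to compound 4 (0.85 log units; beyond the scatter) and remains uncertain. The estimate for compound 4 is 700 nM with an expected range from 200 nM to 2500 nM around it.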

Compound 4, half-maximal inhibitory concentration: 5000 nM
Estimate against measurement, compound 4: 7.1-fold (0.85 log units) below, and the stated range ends below it.
By their numbers in this assay, from the lowest: compound 2; then compound 1; then compounds 3 and 4 (each within the scatter of the next).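

In this assay, replacing methoxy with chloro on the aromatic carbon para to a large group gives no change at the digits printed from compound 3 to compound 4 (within the scatter), so the 4-chlorophenyl group alone does not bring the lower number that compound 2 had seemed to support. The gap to compound 2 comes with a different change, 1H-indol-4-yl in place of 1H-indol-5-yl on a nitrogen on an aromatic ring, which gives a 20-fold higher number from compound 2 to compound 4 (1.30 log units; beyond the scatter), while 4-chlorophenyl in place of 2,4-difluorophenyl on a sulfonyl sulfur gives a 6.7-fold higher number from compound 1 to compound 4 (0.82 log units; beyond the scatter), so the 2,4-difluorophenyl group holds its lower number against both the 4-chlorophenyl and the 4-methoxyphenyl group. No other measurement is available to explain these steps.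

Still open, as far as these compounds go, is whether another group on that same aromatic carbon, such as an amine or a carboxylic acid, would move the number away from where compound 3 and compound 4 stand. Also open, from the compounds shown here alone, is whether the 1H-indol-5-yl group would keep its lower number with 2,4-difluorophenyl or 4-methoxyphenyl on the sulfonyl sulfur.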